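The source may report more compounds than this note shows. Statements on the series, on what has been measured and on what is new or still open speak of the compounds shown alone.

For the measured compounds named here, compound 1 `COc1ccc(-c2nnc(Nc3csc(-c4ccccc4)c3)s2)cc1` is the only compound here with a reported result. In a functional assay on SK-MEL-28 cells (Homo sapiens) for inhibition, read by colorimetric assay and MTT assay, with a stated time of 72 h (a lower number here means a stronger inhibitor, a higher number a weaker inhibitor), compound 1 gives > 100000 nM, which is a limit of the assay rather than a number. Compound 2 `COc1ccc(-c2nnc(Nc3csc(-c4ccc(C)cc4)c3)s2)cc1` shares the same core. In this assay, going by the values given here, compound 2 gives "not determined" (no result reported), so no number stands for it, and the only other value shown sits at the limit of > 100000 nM in this assay, at which 1 of the 2 values shown sits. Compound 3 `Cc1ccc(-c2cc(Nc3nnc(-c4ccc(O)cc4)s3)cs2)cc1` has yet to be tested; it differs from compound 2 by hydrogen in place of methyl on an oxygen on an aromatic ring. Among the compounds with values here, with no measured step between any two compounds, no direction for this change can be set beyond the scatter, and the single reading at the limit of > 100000 nM in this assay, at which 1 of the 2 values shown sits, leaves weak inhibition as the only point of reference. Compound 3 is therefore expected to give about 100000 nM in this assay, within a range from 20000 nM to 300000 nM, most probably reported again only as a limit.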

Compound 3, half-maximal inhibitory concentration: 14000 nM
The estimate for compound 3 lay 7.1-fold (0.85 log units) above the measured number; the measured number lies below the stated range.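

For the compounds shown here, compound 3 gives 14000 nM, but compound 2 has no number to set against it, so no step between these two compounds can be read. The compounds shown leave open how far the change from 4-methoxyphenyl to 4-hydroxyphenyl alone shifts inhibition.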